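This account rests on a few compounds, and the source may have more. Where it says the series, first, only, none or still open, it means among the compounds named here.

Working notes on the series.

Three compounds have been run in a functional assay on BMDM cells (Mus musculus, strain C57BL/6) for inhibition, with a stated time of 2 days; on this read-out lower numbers stand for stronger inhibition and higher numbers for weaker inhibition. Compound 1 `Cc1cc(NC(=O)Cn2cc(-c3ccc(Cl)cc3)nn2)no1` gives 1910 nM in this assay. Compound 2 `Cc1cc(NC(=O)Cn2cc(-c3ccc([N+](=O)[O-])cc3)nn2)no1` is the nitro analogue of compound 1. In this assay compound 2 gives 1220 nM. Compound 3 `CCOC(=O)c1sc(NC(=O)Cn2cc(-c3ccc([N+](=O)[O-])cc3)nn2)nc1C` carries the nitro group of compound 2 on a different core. In this assay compound 3 gives 1840 nM. The difference between the two cores is not broken down here, and the values of compound 2 and compound 3 sit within the scatter of each other.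

Among the compounds with values here, the one counted step so far is the exchange on the phenyl ring, (chloro in place of nitro on an aromatic carbon), which gave a 1.6-fold higher number from compound 2 to compound 1 (0.19 log units; within the scatter). Since the two values lie within the scatter, nothing can be said of an order between compound 2 and compound 1.

Compound 4 `CCOC(=O)c1sc(NC(=O)Cn2cc(-c3ccc(Cl)cc3)nn2)nc1C` has not yet been measured. It relates to compound 3 exactly as compound 1 relates to compound 2: chloro in place of nitro on an aromatic carbon. The place of the change is the same in both pairs, so this is the same change made a second time. Because a 1.6-fold higher number from compound 2 to compound 1 (0.19 log units; within the scatter) was within the scatter, the expected step in this assay is a 1.5-fold higher number from compound 3 to compound 4 (0.18 log units; within the scatter), a small shift in the same direction and likewise within the scatter. Compound 4 is accordingly expected to give about 2800 nM in this assay, with a likely range from 1400 nM to 5600 nM.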

Compound 4, half-maximal inhibitory concentration: 180 nM
Beside the measured number, compound 4's estimate is 16-fold (1.19 log units) above it; measured number outside the range, below it.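

In this assay, chloro in place of nitro on the phenyl ring gives a 10-fold lower number from compound 3 to compound 4 (1.01 log units; beyond the scatter), a large step on this core, whereas the same exchange on the other core stays within the scatter. The exchange therefore does not carry over from one core to the other with the same size, and the two steps differ: the same change on two cores in this assay, a 1.6-fold higher number (0.19 log units; within the scatter) from compound 2 to compound 1 and a 10-fold lower number (1.01 log units; beyond the scatter) from compound 3 to compound 4, 16-fold (1.20 log units) apart, beyond the scatter of two such steps This shows that, in these two pairs, the outcome of the exchange depends on the core that carries it, but it does not show which part of the core is responsible, and it gives no rule beyond these four compounds.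

The compounds shown leave open whether another group in place of the chloro, such as methoxy or an amine, would also give a step that differs between the two cores. They also leave open how much the ethyl ester contributes, which a carboxylic acid or an amide in its place on the core of compound 4 could test.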